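The source may report more compounds than this note shows. Statements on the series, on what has been measured and on what is new or still open speak of the compounds shown alone.

Of the compounds shown here, three have been tested so far, all in an assay on isolated protein for binding affinity to 5-hydroxytryptamine receptor 4 (Homo sapiens); on this read-out lower numbers stand for stronger inhibition and higher numbers for weaker inhibition. Compound 1 `Cc1cccc(-c2n[nH]cc2N2CCCNCC2)c1` carries a methyl on its aromatic ring, and in this assay compound 1 gives only a limit, > 10000 nM. Compound 2 `Fc1cccc(-c2n[nH]cc2N2CCCNCC2)c1` is its fluoro counterpart, and in this assay compound 2 likewise gives a limit, > 10000 nM. Compound 3 `Fc1ccc(-c2n[nH]cc2N2CCNCC2)cc1` has a different core from compound 2; how the two cores differ is not broken down here. In this assay compound 3 also gives a limit, > 10000 nM.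

Compound 2 and compound 1 differ by methyl in place of fluoro on an aromatic carbon, and the step that the two limits leave unreadable from compound 2 to compound 1 cannot be read, since (the limit of > 10000 nM in this assay, at which 3 of the 3 values shown sit).

Compound 4 `Cc1ccc(-c2n[nH]cc2N2CCNCC2)cc1` is not yet measured. It differs from compound 3 by methyl in place of fluoro on an aromatic carbon. This is the same kind of change as from compound 2 to compound 1, but not the same: in one case the group sits meta to a large group, in the other para to a large group.

The step from compound 3 to compound 4 is expected to be a step that the limit leaves unreadable from compound 3 to compound 4, an expectation resting on the fact that all three measured compounds, including compound 3 with > 10000 nM, sit at the assay limit. Compound 4 is therefore expected to come out near 20000 nM, with a plausible range from 7000 nM to 100000 nM, most likely again as a limit rather than a number.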

Compound 4, inhibition constant: > 10000 nM
Compound 4: no number, only a limit; the forecaster's own chance of this, stated with the estimate: 85%; the middle value does not contradict the limit.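

No size can be read for the swap of fluoro for methyl between compound 3 and compound 4, because both give only a limit in this assay and no number: the limit of > 10000 nM in this assay, at which 4 of the 4 values shown sit.

The compounds shown leave open whether methyl or fluoro on the aromatic ring, or the difference between the two cores, changes binding to this receptor at all, since every result is a limit.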